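This account rests on a few compounds, and the source may have more. Where it says the series, first, only, none or still open, it means among the compounds named here.

Of the compounds shown here, two sharing one core have been read so far in an ADME assay on L929 cells (Mus musculus) for cytotoxicity, read by resazurin assay, with a stated time of 96 h (on this read-out higher numbers stand for lower toxicity in this test and lower numbers for higher toxicity in this test), and neither gave an exact number. Compound 1 `NC(=S)N/N=C(\COc1cccc(Cl)c1)c1ccc(Br)cc1` gives < 50200 nM, which is a limit and not a number. Compound 2 `NC(=S)N/N=C(\COc1ccc(Cl)cc1)c1ccc(Br)cc1` gives < 25100 nM, which is also a limit. Going by the values given here, compound 2 therefore has no exact position on this scale, and the only other value available to compare it with is a limit too.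

The next compound is compound 3 `NC(=S)N/N=C(\COc1cccc(Br)c1)c1ccc(Br)cc1`, and the change is 3-bromophenyl in place of 4-chlorophenyl on an oxygen on a saturated carbon. In words, 3-bromophenyl stands in place of 4-chlorophenyl on an oxygen on a saturated carbon. Among the compounds with values here, only one measured step bears on this change, a step that the two limits leave unreadable from compound 1 to compound 2, which swaps 3-chlorophenyl for 4-chlorophenyl at the same place. It offers no size to carry over, so no step beyond the scatter is expected in this assay, and no direction can be argued. The expected outcome is a step that the limit leaves unreadable from compound 2 to compound 3. For compound 3 the estimated half-maximal cytotoxic concentration is 18000 nM, with an expected range from 6000 nM to 40000 nM, and the assay may again report only a limit.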

Compound 3, half-maximal cytotoxic concentration: > 180000 nM
Compound 3: only a limit was reported (the forecaster's own chance of this, stated with the estimate: 65%); middle value at least 10-fold (1.00 log units) away from the limit.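

In this assay compound 3 gives > 180000 nM, which is a limit and not a number. The earlier step between 3-chlorophenyl and 4-chlorophenyl could not be read from its two limits, but this result shows that the group on an oxygen on a saturated carbon can move this read-out, as 3-bromophenyl in place of 4-chlorophenyl gives an at least 7.1-fold higher number from compound 2 to compound 3 (0.85 log units; beyond the scatter), in the direction of lower toxicity in this test. Bromo in place of chloro on an aromatic carbon gives an at least 3.5-fold higher number from compound 1 to compound 3 (0.55 log units; beyond the scatter), so exchanging the halogen alone is enough to separate two compounds on this scale, and the step is again toward lower toxicity in this test.

The true size of both steps stays unread, and the data give only a bound on them: the limit of > 180000 nM in this assay, at which 1 of the 3 values shown sits. Also open, from the compounds shown here alone, is whether 4-bromophenyl would give as high a number as 3-bromophenyl, and whether a methoxy group or an amine in place of the halogen would keep the number high.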